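The source may hold more compounds than are shown below. What is called first, only, known or untested is meant among the compounds shown, and "the series" means these compounds.

Measured compounds in an assay on isolated protein for inhibition of Trypsin (Homo sapiens), read by spectrophotometry, with a stated time of 15 min; on this read-out lower numbers stand for stronger inhibition and higher numbers for weaker inhibition:
Compound 1 `O=C(NC[C@H]1CN(c2ccc(N3CCC(C(=O)O)CC3=O)cc2)C(=O)O1)c1ccc(Cl)s1` gives > 100000 nM, which is a limit of the assay and not a number.
Compound 2 `O=C(NC[C@H]1CN(c2ccc(N3CCCC(C(=O)O)C3)cc2)C(=O)O1)c1ccc(Cl)s1` gives > 100000 nM, again a limit of the assay.
Compound 3 `CCOC(=O)C1CCCN(c2ccc(N3C[C@H](CNC(=O)c4ccc(Cl)s4)OC3=O)cc2)C1` gives > 100000 nM, also a limit of the assay.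

All three values sit at the limit of > 100000 nM in this assay, at which 3 of the 3 values shown sit, so none of the steps between them can be read: a step that the two limits leave unreadable from compound 1 to compound 2, a step that the two limits leave unreadable from compound 1 to compound 3 and a step that the two limits leave unreadable from compound 2 to compound 3. The change from compound 2 to compound 3 is ethyl in place of hydrogen on an oxygen next to a carbonyl group. Compound 4 `CCOC(=O)C1CCN(c2ccc(N3C[C@H](CNC(=O)c4ccc(Cl)s4)OC3=O)cc2)C(=O)C1` carries the same change made on compound 1: ethyl in place of hydrogen on an oxygen next to a carbonyl group. The place of the change reads the same word for word in both pairs, so this is the same change. The two cores differ in this way: 4-carboxy-2-oxopiperidin-1-yl in place of 3-carboxypiperidin-1-yl on an aromatic carbon. Since compound 3 already carries the ethyl ester and shows only the limit > 100000 nM, no sign of measurable inhibition appears anywhere in this set. The step from compound 1 to compound 4 is therefore expected to be unreadable as well, around a number no higher from compound 1 to compound 4 (the limit leaves the size open) in this assay. Compound 4 is expected to give 100000 nM, in a range from 50000 nM to 300000 nM, most likely reported once more as a limit.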

Compound 4, inhibition constant: > 100000 nM
Compound 4 gave a limit, no number; the forecaster's own chance of this, stated with the estimate: 85%; the middle value lies on the limit itself.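

Compound 4, like compound 1, gives a limit of the assay and not a number, so the step between these two compounds cannot be read: the limit of > 100000 nM in this assay, at which 4 of the 4 values shown sit. The compounds shown leave open what ethyl in place of hydrogen, or any other change among them, does to inhibition in this assay, as none of them gives a measured number there.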